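This account rests on a few compounds, and the source may have more. Where it says the series, first, only, none or still open, it means among the compounds named here.

Of the compounds shown here, three sharing one core have been tested in a functional assay on HeLa cells (Homo sapiens) for cytotoxicity, read by MTT assay, with a stated time of 2 days; on this read-out higher numbers stand for weaker inhibition and lower numbers for stronger inhibition. Compound 1 `O=c1[nH]c(-c2cccc3ccccc23)nc2ccc(N3CCCCC3)cc12` gives 330 nM. Compound 2 `Cc1ccc2nc(-c3cccc(F)c3)[nH]c(=O)c2c1` returns only a limit of the assay, > 50000 nM, so no number is known for it. Compound 3 `Cc1ccc2nc(-c3ccccc3C(F)(F)F)[nH]c(=O)c2c1` gives 2450 nM. Of the two actual numbers, compound 3 stands at the higher one, making it the weaker inhibitor of that pair; the nearest number is that of compound 1, and the gap between them is wider than the usual scatter of repeated measurements. Compound 2 sits at the limit of > 50000 nM in this assay, at which 1 of the 3 values shown sits, which is a limit and not a number.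

Compound 4 `Cc1ccc2nc(-c3ccccc3N(C)C)[nH]c(=O)c2c1` has not yet been measured. It differs from compound 3 in one place: dimethylamino in place of trifluoromethyl on an aromatic carbon. No measured pair among these compounds differs in just this way, so no measured step guides the expectation. The change exchanges one small group for another on the same aromatic carbon, ortho to a large group, and in this assay only a modest shift is expected, in either direction, most likely none beyond the scatter. For compound 4 the estimated value is 3000 nM, with a range from 700 nM to 15000 nM, which would mean an expected step of a 1.2-fold higher number from compound 3 to compound 4 (0.09 log units; within the scatter).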

Compound 4, half-maximal inhibitory concentration: 14000 nM
Compound 4: the middle estimate sits 4.7-fold (0.67 log units) below what was measured; measured number inside the range.
By their numbers in this assay, from the lowest: compound 1; then compound 3; then compound 4. At a limit, above all of these: compound 2.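

In this assay the exchange of trifluoromethyl for dimethylamino on an aromatic carbon, ortho to a large group, gives a 5.7-fold higher number from compound 3 to compound 4 (0.76 log units; beyond the scatter) and so shows that this position is not indifferent to which small group it carries. This is the first pair among the compounds shown that differs in one place only, and it links a single change to a weaker result, with dimethylamino the less favourable of the two groups on this carbon. Nothing measured here explains why the number moves.

The compounds shown leave open how a methoxy group, a chlorine atom or a plain hydrogen on the same aromatic carbon would compare, so this one step cannot say whether the loss of trifluoromethyl or the arrival of dimethylamino counts for more. They also leave open whether the same exchange would shift the number by a similar amount on a compound that otherwise resembles compound 1, whose other substituents differ from those of compound 3 and compound 4.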